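This account rests on a few compounds, and the source may have more. Where it says the series, first, only, none or still open, it means among the compounds named here.

Working notes on the series.

Compound 1 is `Cn1cnnc1SCC(=O)N/N=c1/scc(-c2ccc(Br)cc2)n1-c1ccccc1`. In a functional assay on C6 cells (Rattus norvegicus) for cytotoxicity, read by MTT assay, with a stated time of 24 h (a higher number here means a weaker inhibitor, a lower number a stronger inhibitor), compound 1 has no reported number, the entry reading "not determined" (no result reported). Compound 2, `Cc1nnc(SCC(=O)N/N=c2/scc(-c3ccc(Br)cc3)n2-c2ccccc2)s1`, likewise stands without a number in this assay, its entry reading "not determined" (no result reported). For the measured compounds named here, the only number in the set belongs to compound 3, `O=C(CSc1nnnn1-c1ccccc1)N/N=c1/scc(-c2ccc(Br)cc2)n1-c1ccccc1`: in this assay compound 3 gives 21 ug/mL. Going by the values given here, compound 1 therefore stands nowhere on the numbers; neither it nor compound 2 can be placed against compound 3, and no step between measured compounds exists.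

Compound 4 is `Cc1ccc(-c2cs/c(=N/NC(=O)CSc3nncn3C)n2-c2ccccc2)cc1`. It differs from compound 1 in one place: methyl in place of bromo on an aromatic carbon. Among the compounds with values here, no measured pair tells what this change does in this assay. With the shared core held and a single group exchanged at one aromatic carbon, no step beyond the scatter is expected in either direction in this assay; the number for compound 3 is the only anchor. For compound 4 the expected value in this assay is 25 ug/mL, within a range of 8 ug/mL to 80 ug/mL.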

Compound 4, half-maximal inhibitory concentration: 56 ug/mL
Compound 4: middle estimate off by 2.2-fold (0.35 log units), on the low side, and the stated range covers the measured number.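

No new step can be read: compound 4 differs in one place from compound 1, which carries no number in this assay to compare with. The compounds shown leave open what going from 4-bromophenyl to 4-methylphenyl does in this assay on this core. No evidence bears on this result.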